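The source may report more compounds than this note shows. Statements on the series, on what has been measured and on what is new or still open speak of the compounds shown alone.

Four compounds share one core and are compared in an ADME assay on HEp-2 cells (Homo sapiens) for cytotoxicity, read by MTT assay, with a stated time of 3 days; on this read-out higher numbers stand for lower toxicity in this test and lower numbers for higher toxicity in this test. Compound 1, `CC[C@@H](CCn1cncn1)c1ccc(F)cc1`, gives 90.3 ug/mL in this assay. Compound 2, `CC[C@@H](CCn1cncn1)c1ccc(C)cc1`, carries a methyl in place of the fluoro on the aromatic ring and gives 69.9 ug/mL in this assay. That change, (methyl in place of fluoro on an aromatic carbon), produced a 1.3-fold lower number from compound 1 to compound 2 (0.11 log units; within the scatter). Compound 3, `CCC[C@H](CCn1cncn1)c1ccc(F)cc1`, has a core that differs from that of compound 1, and the difference between the two cores is not broken down here; in this assay compound 3 gives 39.3 ug/mL, a value that sits beyond the scatter from compound 1 but within the scatter of compound 2. Compound 4, `CCC[C@H](CCn1cncn1)c1ccc(C)cc1`, is not yet measured. Among the measured compounds shown here, it differs from compound 3 by methyl in place of fluoro on an aromatic carbon, which is the same change as the one from compound 1 to compound 2. Because the first such change gave a 1.3-fold lower number from compound 1 to compound 2 (0.11 log units; within the scatter), a step of similar size is expected here, namely a 1.3-fold lower number from compound 3 to compound 4 (0.12 log units; within the scatter). On that basis compound 4 is estimated at 30 ug/mL in this assay, within a range from 15 ug/mL to 60 ug/mL.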

Compound 4, half-maximal cytotoxic concentration: 45.7 ug/mL
Beside the measured number, compound 4's estimate is 1.5-fold (0.18 log units) below it; low and high end bracket the measured number.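

In this assay, methyl in place of fluoro on the aromatic carbon gives a 1.2-fold higher number from compound 3 to compound 4 (0.07 log units; within the scatter), a step too small to be told apart from repeat-measurement noise. Set beside the same change on the other core, this step shows no real difference between the two cores: the same change on two cores in this assay, a 1.3-fold lower number (0.11 log units; within the scatter) from compound 1 to compound 2 and a 1.2-fold higher number (0.07 log units; within the scatter) from compound 3 to compound 4, 1.5-fold (0.18 log units) apart, within the scatter of two such steps Within this series, then, swapping fluoro for methyl can be carried from one of these cores to the other with little effect on the number, but two pairs of compounds show this for these two cores only and do not show that it would hold on any other core, nor why the swap matters so little here.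

The compounds shown carry only fluoro or methyl at this place on the ring, so it remains open how an amine, a carboxylic acid or a methoxy group there would read in this test. Also open, on these data alone, is whether the swap would stay this small on a core with a longer chain.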